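Estimating Compound 3 From a Single Anchor Value

A few compounds are considered here, and "the series" means these few. Any claim that something is new, unique, unknown or untested is made for them only; others in the source may bear on it.

Compound 1 `CCCCc1ccc2[nH]c(-c3ccc(C(F)(F)F)cc3)c(/C=N/NC(=O)c3ccccc3)c2c1`: 460 nM
Compound 2 `CCCCc1ccc2[nH]c(-c3ccc(OC)cc3)c(/C=N/NC(=O)c3cccc(OC)c3)c2c1`: "not determined" (no result reported)

All numbers here come from a functional assay on MCF7 cells (Homo sapiens) for antiproliferative activity, with a stated time of 5 days; a lower number here means a stronger inhibitor, a higher number a weaker inhibitor. Within the data shown here, compound 2 stands without a value in this assay, so the only foothold is compound 1 , which in this assay gives 460 nM. Compound 3 `CCCCc1ccc2[nH]c(-c3ccc(OC)cc3)c(/C=N/NC(=O)c3cccnc3)c2c1` differs from compound 2 in one place: pyridin-3-yl in place of 3-methoxyphenyl on a carbonyl carbon. Among the measured compounds shown here, no measured pair shows this swap, so its size and direction are unknown; no shift beyond the scatter is assumed. Compound 3 is expected to give about 500 nM in this assay, with a range of 120 nM to 2500 nM.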

Compound 3, half-maximal inhibitory concentration: 75 nM
Estimate against measurement, compound 3: 6.7-fold (0.82 log units) above; the measured number lies below the stated range.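

Compound 2 has no value to set against compound 3 in this assay, so no step can be read between them. The compounds shown leave open what swapping 3-methoxyphenyl for pyridin-3-yl does to potency. No supporting evidence bears on this result.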